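The source may hold more compounds than are shown below. What is called first, only, known or untested is meant among the compounds shown, and "the series" means these compounds.

Measured compounds in an ADME assay on Vero cells (Chlorocebus sabaeus) for cytotoxicity, with a stated time of 72 h; on this read-out higher numbers stand for lower toxicity in this test and lower numbers for higher toxicity in this test:
- compound 1 `CN1CCN(c2ccc(C(=O)C3CC3c3ccc(Cl)cc3)cc2)CC1`: 82.1 ug/mL
- compound 2 `CC(C)CCCC(C)Nc1ccc(C(=O)C2CC2c2ccc(Cl)cc2)cc1`: "not determined" (no result reported)
- compound 3 `O=C(c1ccc(N2CCCCC2)cc1)C1CC1c1ccc(Cl)cc1`: 284 ug/mL

Among the compounds with values here, compound 1 gives the lower of the two numbers in this assay; the only neighbour with a number, compound 3, shows a 3.5-fold higher number from compound 1 to compound 3 (0.54 log units; beyond the scatter), a modest step, and compound 2 has no result. Compound 4 `O=C(c1ccc(NCCn2cncn2)cc1)C1CC1c1ccc(Cl)cc1` differs from compound 1 in one place: (2-(1H-1,2,4-triazol-1-yl)ethyl)amino in place of 4-methylpiperazin-1-yl on an aromatic carbon. Within the data shown here, the sole measured step, from compound 1 to compound 3, bears on this only loosely, since there a ring amine replaced a ring amine, whereas here the group that enters is an open chain carrying a triazole. That step was modest, and a similar or smaller shift is expected. For compound 4 the estimate in this assay is 120 ug/mL, within 50 ug/mL to 300 ug/mL, which means an expected step of a 1.5-fold higher number from compound 1 to compound 4 (0.16 log units; within the scatter).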

Compound 4, half-maximal cytotoxic concentration: 39.9 ug/mL
For compound 4 the middle estimate is 3.0-fold (0.48 log units) above the measured one; measured number below the stated range.
By their numbers in this assay, from the lowest: compound 4; then compound 1; then compound 3.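

In this assay this place on the aromatic ring can move the number in either direction from the 4-methylpiperazin-1-yl of compound 1: the open chain carrying a triazole gives a 2.1-fold lower number from compound 1 to compound 4 (0.31 log units; beyond the scatter), against the rise seen with piperidin-1-yl in a 3.5-fold higher number from compound 1 to compound 3 (0.54 log units; beyond the scatter). Set against piperidin-1-yl, the same chain gives a 7.1-fold lower number from compound 3 to compound 4 (0.85 log units; beyond the scatter), the widest step among the compounds with numbers. No measurement explains these steps.

Going by these compounds, whether the lower number goes with the triazole ring or with the open ethylamino chain remains open. An imidazole in place of the triazole, or a plain 2-methoxyethylamino chain, would separate the two.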